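The compounds below may be only part of what the source reports. "The series", "measured", "known", "first", "only" and "open" are said of these compounds alone.

Working notes on the series. Compound 1 `Nc1cc(N)c2nc(-c3ccccc3)c(Oc3ccc(Cl)c(Cl)c3)nc2c1`, compound 2 `CCOC(=O)[C@H](CCC(=O)O)NC(=O)c1ccc(CNc2nc3cc(N)cc(N)c3nc2-c2ccccc2)cc1` and compound 3 `CCOC(=O)[C@H](CCC(=O)O)NC(=O)c1ccc(Oc2nc3cc(N)cc(N)c3nc2-c2ccccc2)cc1` share one core and differ in the group attached to it. In a functional assay on NCI-H460 cells (Homo sapiens) for inhibition, read by sulforhodamine B assay, with a stated time of 48 h (on this read-out lower numbers stand for stronger inhibition of growth and higher numbers for weaker inhibition of growth), compound 1 gives 18200 nM, compound 2 gives 31600 nM and compound 3 gives 95500 nM. Compound 1 has the lowest number of the three, but compound 2 lies within the scatter of it and cannot be separated from it; only compound 3 stands beyond the scatter from compound 1.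

Compound 4 `COc1ccc(Sc2nc3cc(N)cc(N)c3nc2-c2ccccc2)cc1` has not been measured. It carries (4-methoxyphenyl)sulfanyl in place of 3,4-dichlorophenoxy on an aromatic carbon. Among the compounds with values here, no measured pair shows this kind of exchange, so the direction of the step is open. The step from compound 1 to compound 4 in this assay is expected to be a 1.4-fold higher number from compound 1 to compound 4 (0.14 log units; within the scatter), no larger than the scatter. Compound 4 is estimated at 25000 nM, between 8000 nM and 80000 nM.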

Compound 4, concentration for 50% growth inhibition: 20000 nM
Compound 4: middle estimate off by 1.3-fold (0.10 log units), on the high side; the measured number falls inside the stated range.
By their numbers in this assay, from the lowest: compounds 1, 4 and 2 (each within the scatter of the next); then compound 3.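

Within the data shown here, this is the first pair that differs in one place, and in this assay the exchange gives a 1.1-fold higher number from compound 1 to compound 4 (0.04 log units; within the scatter). At this aromatic carbon, (4-methoxyphenyl)sulfanyl can therefore stand in for 3,4-dichlorophenoxy with no separable change in growth inhibition. No measurement at hand explains this result.

Going by these compounds, the linking atom and the ring substituents change together, so their separate contributions remain open. Also open, on these data alone, is whether a group without an aromatic ring at this carbon, such as a simple amine or a carboxylic acid, would keep this level of growth inhibition.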